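The source may report more compounds than this note shows. Statements on the series, on what has been measured and on what is new or still open speak of the compounds shown alone.

Of the compounds shown here, two from this series have so far been tested in a functional assay on the whole organism (strain albino) for inhibition, with Rattus norvegicus as the target, read by paw edema, with stated times of 1 h and 3 h, at a dose of 20 mmol/kg by the intraperitoneal route; on this read-out higher numbers stand for a stronger effect at the one dose given and lower numbers for a weaker effect. Compound 1 `N#CC1=C(NCC(=O)O)N(c2ccccc2)C(=O)N2CCCCC(N3CCCC3)C12` gives 89.2% in this assay, while compound 2 `N#CC1=C(/N=C/Nc2ccc([N+](=O)[O-])cc2)N(c2ccccc2)C(=O)N2CCCCC(N3CCCC3)C12` gives 85.6% in this assay. Compound 2 thus stands at the lower of the two figures, yet the step of a number 3.6 percentage points lower from compound 1 to compound 2 (within the scatter) lies within the usual scatter, so the two compounds cannot be told apart on this read-out.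

Compound 3 `COc1ccc(N/C=N/C2=C(C#N)C3C(N4CCCC4)CCCCN3C(=O)N2c2ccccc2)cc1` has not yet been measured. It differs from compound 2 by methoxy in place of nitro on an aromatic carbon. Within the data shown here, no measured step touches this part of the molecule: the only step available, a number 3.6 percentage points lower from compound 1 to compound 2 (within the scatter), concerns the exchange of the whole side group on the double-bonded ring carbon and was itself within the scatter. The data therefore give no ground to expect a shift beyond the scatter in this assay, in either direction.

For compound 3 the expected value in this assay is estimated at 84%, with a range from 73% to 92%. This estimate corresponds to a step of a number 1.6 percentage points lower from compound 2 to compound 3 (within the scatter), which is expected to remain within the scatter.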

Compound 3, a percentage reported as inhibition, in the whole organism at one dose (the size of the read-out at that dose, not a potency): 50.2%
Beside the measured number, compound 3's estimate is 33.8 percentage points above it; the whole stated range lies above it.
By their numbers in this assay, from the lowest: compound 3; then compounds 2 and 1 (each within the scatter of the next).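

In this assay, among these compounds, the para position of this aromatic ring proves to be a sensitive place: methoxy in place of nitro gives a number 35.4 percentage points lower from compound 2 to compound 3 (beyond the scatter), although only this one group on the molecule differs. The earlier step, a number 3.6 percentage points lower from compound 1 to compound 2 (within the scatter), had suggested that the large side group on the double-bonded ring carbon could replace the smaller one without consequence, but a number 39 percentage points lower from compound 1 to compound 3 (beyond the scatter) shows that this holds for the 4-nitrophenyl form and not for the 4-methoxyphenyl form, so the outcome of that exchange depends on the group carried by the aromatic ring. Nothing available explains why nitro and methoxy differ so far in this read-out.

The compounds shown leave open whether the fall follows from the loss of nitro or from the arrival of methoxy, a question that an unsubstituted phenyl ring, a chlorine atom or an amino group on the same carbon could help to separate. They also leave open whether a longer ether such as ethoxy, or a nitrile in that place, would stay with compound 2 or with compound 3 in this assay.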